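The compounds below may be only part of what the source reports. "The series", "measured", "known", "first", "only" and "open" are said of these compounds alone.

Of the compounds shown here, two have numbers so far. In a functional assay on A549 cells (Homo sapiens) for cytotoxicity, read by colorimetric assay and MTT assay, with a stated time of 3 days, tested at 1 uM (on this read-out lower numbers stand for a stronger effect and higher numbers for a weaker effect at the one concentration tested), compound 1 `COc1ccc(-c2nc(-c3ccccc3)c(-c3ccc4c(c3)NC(=O)CO4)[nH]2)cc1` gives 101%, and compound 2 `O=C1COc2ccc(-c3[nH]c(-c4c[nH]c5ncccc45)nc3-c3ccccc3)cc2N1` gives 100%. For the measured compounds named here, the one measured step, a number 1 percentage points lower from compound 1 to compound 2 (within the scatter), lies within the scatter, so compound 2 stands level with compound 1 on these two numbers. Compound 3 `O=C1COc2ccc(-c3[nH]c(-c4ccccc4)nc3-c3ccccc3)cc2N1` differs from compound 2 by a group of 6 heavy atoms (6 carbon; one six-membered aromatic ring of carbon only) in place of a group of 9 heavy atoms (7 carbon, 2 nitrogen; one five-membered aromatic ring with 1 hetero atom, one six-membered aromatic ring with 1 hetero atom), on an aromatic carbon. Going by the values given here, no measured step covers this change; the only step available, a number 1 percentage points lower from compound 1 to compound 2 (within the scatter), was flat, and both measured compounds read close to the untreated level in this assay. The expected step is no change at the digits printed from compound 2 to compound 3 (within the scatter), not beyond the scatter. The estimated value for compound 3 is 100%, with a range of 88% to 108%.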

Compound 3, a percentage reported as activity, at one concentration (the size of the read-out at that concentration, not a potency): 95.6%
Beside the measured number, compound 3's estimate is 4.4 percentage points above it, and the stated range covers the measured number.
By their numbers in this assay, from the lowest: compounds 3, 2 and 1 (each within the scatter of the next).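

In this assay, phenyl on the ring carbon between two ring nitrogen atoms, in place of the larger two-ring group, gives a number 4.4 percentage points lower from compound 2 to compound 3 (within the scatter), and hydrogen in place of methoxy on an aromatic carbon gives a number 5.4 percentage points lower from compound 1 to compound 3 (within the scatter). This position therefore accepts phenyl, methoxy-bearing or two-ring groups with no step beyond the scatter, so the read-out does not separate them at this concentration. Nothing available accounts for these flat readings.

From the compounds shown here alone, whether an amine or a carboxylic acid at this position would move the number stays open. So does whether any change to the shared core would give a step beyond the scatter.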